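Fluorine on the Distal Phenyl of a Triazole Amide

The source may report more compounds than this note shows. Statements on the series, on what has been measured and on what is new or still open speak of the compounds shown alone.

Compound 1 `COc1ccc(Cn2cc(CNC(=O)c3cn(-c4ccccc4)nc3-c3ccccc3)nn2)cc1`: 10200 nM
Compound 2 `COc1cc(Cn2cc(CNC(=O)c3cn(-c4ccccc4)nc3-c3ccccc3)nn2)cc(OC)c1`: 190 nM
Compound 3 `COc1cc(Cn2cc(CNC(=O)c3cn(-c4ccccc4)nc3-c3ccccc3)nn2)cc(OC)c1OC`: 1000 nM

In a functional assay on MIA PaCa-2 cells (Homo sapiens) for antiproliferative activity, read by sulforhodamine B assay, with a stated time of 48 h (a higher number here means a weaker inhibitor of growth, a lower number a stronger inhibitor of growth), compound 2 gives the lowest of the three numbers, separated from compound 3 by a 5.3-fold higher number from compound 2 to compound 3 (0.72 log units; beyond the scatter) and from compound 1 by a 54-fold lower number from compound 1 to compound 2 (1.73 log units; beyond the scatter). Compound 4 `COc1cc(Cn2cc(CNC(=O)c3cn(-c4ccccc4)nc3-c3ccc(F)cc3)nn2)cc(OC)c1` differs from compound 2 by fluoro in place of hydrogen on an aromatic carbon. For the measured compounds named here, none of the measured steps touches this phenyl: a 54-fold lower number from compound 1 to compound 2 (1.73 log units; beyond the scatter), a 10-fold lower number from compound 1 to compound 3 (1.01 log units; beyond the scatter) and a 5.3-fold higher number from compound 2 to compound 3 (0.72 log units; beyond the scatter) all concern the ring on the saturated chain carbon bound to the aromatic nitrogen. Going by the values given here, with no comparable step in hand, compound 4 is expected to give a step within the scatter, no change at the digits printed from compound 2 to compound 4 (within the scatter). Compound 4 is therefore estimated at 190 nM, within a range of 70 nM to 550 nM.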

Compound 4, concentration for 50% growth inhibition: 190 nM
The estimate for compound 4 equals the measured number at the digits printed; measured number inside the range.
By their numbers in this assay, from the lowest: compounds 2 and 4 (each within the scatter of the next); then compound 3; then compound 1.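

The change from phenyl to 4-fluorophenyl is the first shown on this ring rather than on the ring at the saturated chain carbon, and in this assay it gives no change at the digits printed from compound 2 to compound 4 (within the scatter) with the 3,5-dimethoxyphenyl group in place. This aromatic carbon, para to a large group, therefore takes a fluoro with no change that stands out from the scatter, unlike the large steps seen at the other ring.

From the compounds shown here alone, whether a larger group, such as an amine, a carboxylic acid or a longer chain, would be tolerated at this carbon remains open. No evidence is available on what lies behind this result.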